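The compounds below may be only part of what the source reports. "The series", "measured", "known", "first", "only" and "open" are said of these compounds alone.

Measured compounds in a functional assay on LNCaP cells (Homo sapiens) for cytotoxicity, read by resazurin assay; on this read-out higher numbers stand for weaker inhibition and lower numbers for stronger inhibition:
- compound 1, `CC1(C)[C@H](Br)[C@H](O)C[C@@]2(CO2)[C@@]12CCC(=O)[C@@H]1O[C@@H]12` — >= 10000 nM
- compound 2, `C=C1C[C@@H](O)[C@@H](Br)C(C)(C)[C@@]12C=C[C@](O)(C(Br)Br)CC2` — >= 10000 nM

Both values in this assay are limits of the assay rather than numbers. For compound 1 this assay reports >= 10000 nM, which is a limit and not a measured number. For compound 2 this assay reports >= 10000 nM, again a limit and not a measured number. Compound 2 therefore stands at the same place as every other value shown, namely (the limit of >= 10000 nM in this assay, at which 2 of the 2 values shown sit). Within the data shown here, no step between measured compounds that differ in one place is available, so the series gives no measured change to lean on.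

Compound 3, `C=C1C[C@@H](O)[C@@H](Br)C(C)(C)[C@@]12C=C[C@](O)(CO)CC2`, differs from compound 2 in one place: hydroxymethyl in place of dibromomethyl on a saturated ring carbon. With compound 2 giving only a limit in this assay, the step from compound 2 to compound 3 is expected to be none beyond the scatter, and the expected step of a number no higher from compound 2 to compound 3 (the limit leaves the size open) reflects that. Compound 3 is accordingly estimated at 10000 nM in this assay, with a range from 4000 nM to 30000 nM, and a further limit is the more likely outcome than a number.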

Compound 3, half-maximal inhibitory concentration: >= 10000 nM
Compound 3 gave a limit, no number; the forecaster's own chance of this, stated with the estimate: 70%; the middle value sits exactly at the limit.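

Compound 2 and compound 3 both give only a limit in this assay, so no step can be read for hydroxymethyl in place of dibromomethyl on a saturated ring carbon: the limit of >= 10000 nM in this assay, at which 3 of the 3 values shown sit.

The compounds shown leave open whether hydroxymethyl and dibromomethyl differ at all in this assay, and what on the shared core would give a measured number.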